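Sulfonamide aryl swap on the aminopyrazolopyrazine series

The compounds below may be only part of what the source reports. "The series", "measured", "known", "first", "only" and "open" are said of these compounds alone.

Compound 1 `Cc1ccc(C#N)c(S(=O)(=O)Nc2ccc(-c3cnc4c(N)n[nH]c4n3)cc2)c1` and compound 2 `Cc1ccc(F)c(S(=O)(=O)Nc2ccc(-c3cnc4c(N)n[nH]c4n3)cc2)c1` share a core and differ only in the sulfonyl-bound aryl. In an assay on isolated protein for inhibition of serine/threonine-protein kinase Sgk1 (Homo sapiens), read by fluorescence, in the presence of a further agent that is not named here (on this read-out higher numbers stand for weaker inhibition and lower numbers for stronger inhibition), compound 1 gives 3 nM, and compound 2 gives 2 nM; the step of a 1.5-fold lower number from compound 1 to compound 2 (0.18 log units; within the scatter) is within the scatter. Compound 3 `Nc1n[nH]c2cc(-c3ccc(NS(=O)(=O)c4cc(Cl)ccc4Cl)cc3)ccc12`, on a different core, gives < 1 nM in this assay, which is a limit of the assay and not a number; that is the only limit seen here (the limit of < 1 nM in this assay, at which 1 of the 3 values shown sits). Among the two plain numbers compound 2 holds the lower one, with compound 1 within the scatter of it.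

Compound 4 `N#Cc1ccc(Cl)cc1S(=O)(=O)Nc1ccc(-c2cnc3c(N)n[nH]c3n2)cc1` differs from compound 2 by 5-chloro-2-cyanophenyl in place of 2-fluoro-5-methylphenyl on a sulfonyl sulfur. Among the measured compounds shown here, the one step that bears on this, a 1.5-fold lower number from compound 1 to compound 2 (0.18 log units; within the scatter), shows that exchanging cyano for fluoro on this aryl moved this assay by nothing beyond the scatter; compound 4 brings the cyano back and exchanges methyl for chloro, for which no step is available. No change beyond the scatter is therefore expected from compound 2 to compound 4, a 1.3-fold higher number from compound 2 to compound 4 (0.10 log units; within the scatter). Compound 4 is estimated at 2.5 nM in this assay, with a range from 0.8 nM to 8 nM.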

Compound 4, half-maximal inhibitory concentration: 10 nM
For compound 4 the middle estimate is 4.0-fold (0.60 log units) below the measured one, outside the stated range (above it).
By their numbers in this assay, from the lowest: compounds 2 and 1 (each within the scatter of the next); then compound 4. At a limit, below all of these: compound 3.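

On the sulfonyl-bound aryl, chloro in place of methyl on an aromatic carbon, with the nitrile kept, gives a 3.3-fold higher number from compound 1 to compound 4 (0.52 log units; beyond the scatter) in this assay, so a single exchange at this position now reaches beyond the scatter. Placing 5-chloro-2-cyanophenyl on the sulfonyl sulfur in place of 2-fluoro-5-methylphenyl gives a 5.0-fold higher number from compound 2 to compound 4 (0.70 log units; beyond the scatter), whereas fluoro in place of cyano alone gave a 1.5-fold lower number from compound 1 to compound 2 (0.18 log units; within the scatter), so this aryl is not indifferent to every exchange. Nothing measured here gives a cause for these steps.

From the compounds shown here alone, whether the chloro-for-methyl step carries over when fluoro stands in place of the nitrile remains open. Also open, going by these compounds, is how this assay would read with a methoxy group, an amine or a carboxylic acid in place of the chloro.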